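This account rests on a few compounds, and the source may have more. Where it says the series, first, only, none or still open, it means among the compounds named here.

Working notes on the series sharing the core of compound 1. In a functional assay on SK-OV-3 cells (Homo sapiens) for antiproliferative activity, read by MTT assay, with a stated time of 72 h (on this read-out higher numbers stand for weaker inhibition and lower numbers for stronger inhibition), compound 1 `O=C(CCc1cccc2c1B(O)OC2)NCc1ccccc1` gives > 100000 nM, which is a limit of the assay and not a number. In this assay compound 2 `O=C(CCc1cccc2c1B(O)OC2)Nc1nccs1` gives > 100000 nM, which is likewise a limit. Among the compounds with values here, the position of compound 2 is therefore known only as a limit, and the series so far is summed up by the limit of > 100000 nM in this assay, at which 2 of the 2 values shown sit.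

Compound 3 `O=C(CCc1cccc2c1B(O)OC2)Nc1ccc(Br)cc1` carries 4-bromophenyl in place of 1,3-thiazol-2-yl on an amide-type nitrogen, the change from compound 2 being (4-bromophenyl in place of 1,3-thiazol-2-yl on an amide-type nitrogen). Within the data shown here, the only measured step, a step that the two limits leave unreadable from compound 1 to compound 2, supplies no size or direction to carry forward. No step beyond the scatter can be argued from it for this assay, so no readable change is expected, and a further report as a limit is the likeliest outcome. The expected step is a number no higher from compound 2 to compound 3 (the limit leaves the size open). For compound 3 the estimated value is 100000 nM, with an expected range of 30000 nM to 300000 nM.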

Compound 3, half-maximal inhibitory concentration: 9200 nM
For compound 3 the middle estimate is 11-fold (1.04 log units) above the measured one; measured number outside the range, below it.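

The group on the amide-type nitrogen is now shown to be able to move the read-out in this assay: 4-bromophenyl in place of 1,3-thiazol-2-yl gives an at least 10-fold lower number from compound 2 to compound 3 (1.03 log units; beyond the scatter) and 4-bromophenyl in place of benzyl gives an at least 10-fold lower number from compound 1 to compound 3 (1.03 log units; beyond the scatter) on the same nitrogen. As far as these compounds go, both steps start from a limit of the assay and not a number, and how far each one extends beyond the printed size stays open. Within the data shown here, compound 3 is the only compound here that reads as a number, and the rest of the series remains at the limit: the limit of > 100000 nM in this assay, at which 2 of the 3 values shown sit.

The compounds shown do not separate the bromine from the aromatic ring that carries it, and a plain phenyl or a chlorophenyl on the same nitrogen would be needed to tell these apart. Nor do they tell how a longer chain linking the shared core to the carbonyl, or a carboxylic acid in place of the amide, would read in this assay on these cells.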